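A few compounds are considered here, and "the series" means these few. Any claim that something is new, unique, unknown or untested is made for them only; others in the source may bear on it.

Compound 1 `Cc1cc(N2CC[C@@H](C)[C@@H](N(C)c3ncnc4[nH]ccc34)C2)n2ncnc2n1` and compound 2 `Cc1cc(N2CC[C@@H](C)[C@@H](N(C)c3ncnc4[nH]ccc34)C2)n2nc(SCCc3ccccc3)nc2n1` share one core and have both been tested in a toxicity assay on GES1 cells (Homo sapiens) for inhibition, read by MTT assay, with a stated time of 72 h; a lower number here means a stronger inhibitor, a higher number a weaker inhibitor. In this assay compound 1 gives 57900 nM, and compound 2 gives 66200 nM. Compound 1 holds the lower of the two numbers, yet the step of a 1.1-fold higher number from compound 1 to compound 2 (0.06 log units; within the scatter) lies within the scatter, so the two compounds cannot be told apart on these data.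

Compound 3 `Cc1cc(N2CC[C@@H](C)[C@@H](N(C)c3ncnc4[nH]ccc34)C2)n2nc(SCc3ccc(F)c(Cl)c3)nc2n1` has not yet been measured. It differs from compound 1 in a single place: (3-chloro-4-fluorobenzyl)sulfanyl in place of hydrogen on an aromatic carbon. For the measured compounds named here, the only measured step that bears on this change is a 1.1-fold higher number from compound 1 to compound 2 (0.06 log units; within the scatter), in which another sulfanyl-linked group entered at the same aromatic carbon and left the number essentially unchanged. On that basis no step beyond the scatter is expected for compound 3 in this assay, in either direction. For compound 3 the expected value is 60000 nM, with a range from 25000 nM to 150000 nM. This estimate corresponds to a step of a 1.0-fold higher number from compound 1 to compound 3 (0.02 log units; within the scatter), which is expected to remain within the scatter.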

Compound 3, half-maximal inhibitory concentration: > 100000 nM
Compound 3: no number, only a limit; the forecaster's own chance of this, stated with the estimate: 15%; middle value at least 1.6-fold (0.22 log units) from the limit.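

In this assay compound 3 gives > 100000 nM, which is a limit of the assay and not a number. At this aromatic carbon, between two ring nitrogen atoms, the entry of (3-chloro-4-fluorobenzyl)sulfanyl gives an at least 1.7-fold higher number from compound 1 to compound 3 (0.23 log units; that floor lies within the scatter), and the swap of 3-chloro-4-fluorophenyl in place of benzyl on the saturated chain carbon bound to the sulfur gives an at least 1.5-fold higher number from compound 2 to compound 3 (0.17 log units; that floor lies within the scatter). So a second sulfanyl-linked group with an aromatic ring at this carbon also shows no move towards a lower number, a stronger inhibitor, but each step is known only as a floor, and that floor lies within the scatter, so its true size stays unknown, with the result resting on a reading at the limit: the limit of > 100000 nM in this assay, at which 1 of the 3 values shown sits.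

The compounds shown leave open whether the chlorine and fluorine atoms play any part, since a plain benzylsulfanyl group, without either halogen, would be needed to separate them from the benzyl ring itself. They also leave open whether a group with no sulfur link at this carbon, such as an amine or a carboxylic acid, would bring the number down towards a stronger inhibitor.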